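The compounds below may be only part of what the source reports. "The series", "measured", "known", "first", "only" and "open" are said of these compounds alone.

Compound 1 `CN(C)C(=O)c1cc2cnc(Nc3ccc(C(=O)NCCCN=C=S)cc3F)nc2n1C1CCCC1`, compound 2 `CN(C)C(=O)c1cc2cnc(Nc3ccc(C(=O)NCCCCN=C=S)cc3F)nc2n1C1CCCC1` and compound 3 `CN(C)C(=O)c1cc2cnc(Nc3ccc(NC(=O)CCCCN=C=S)cc3)nc2n1C1CCCC1` share a common core and each carries a chain that ends in the same group. All three were tested in a functional assay on NCI-H1299 cells (Homo sapiens) for inhibition, read by CCK-8 assay, with a stated time of 72 h, tested at 1 uM; on this read-out higher numbers stand for a stronger effect at the one concentration tested and lower numbers for a weaker effect. In that test compound 1 gives 9.27%, compound 2 gives 28.7%, and compound 3 gives 58.6%, the highest of the three.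

Compound 1 and compound 2 differ in one place: a group of 4 heavy atoms (2 carbon, 1 nitrogen, 1 sulfur; no ring) in place of a group of 3 heavy atoms (1 carbon, 1 nitrogen, 1 sulfur; no ring), on a saturated chain carbon, three bonds along the chain from an amide-type nitrogen. The result of that change was a number 19.4 percentage points higher from compound 1 to compound 2 (beyond the scatter). How the core of compound 3 differs from that of compound 1 is not broken down here, as the two differ in more than one place.

Compound 4 `CN(C)C(=O)c1cc2cnc(Nc3ccc(NC(=O)CCCCCN=C=S)cc3)nc2n1C1CCCC1` has not yet been measured in this assay. It differs from compound 3 in one place: a group of 4 heavy atoms (2 carbon, 1 nitrogen, 1 sulfur; no ring) in place of a group of 3 heavy atoms (1 carbon, 1 nitrogen, 1 sulfur; no ring), on a saturated chain carbon, four bonds along the chain from a carbonyl carbon. For the measured compounds named here, this is the same kind of change as the one between compound 1 and compound 2, though not the same: there it sat three bonds along the chain from an amide-type nitrogen, here it sits four bonds along the chain from a carbonyl carbon.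

The step expected here is a number 11.4 percentage points higher from compound 3 to compound 4 (beyond the scatter), a smaller rise than the earlier one, because a number 19.4 percentage points higher from compound 1 to compound 2 (beyond the scatter) was an increase, and because compound 3 already gives 58.6% there is less room upward. Compound 4 is therefore estimated at 70%, with a range from 50% to 88%.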

Compound 4, a percentage reported as inhibition, at one concentration (the size of the read-out at that concentration, not a potency): 34.3%
The estimate for compound 4 lay 35.7 percentage points above the measured number; the measured number lies below the stated range.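

In this assay, putting the group of 4 heavy atoms in place of the group of 3 heavy atoms, on a saturated chain carbon, gave a number 24.3 percentage points lower from compound 3 to compound 4 (beyond the scatter), so the two steps run in opposite directions on the two cores: the same change on two cores in this assay, a number 19.4 percentage points higher (beyond the scatter) from compound 1 to compound 2 and a number 24.3 percentage points lower (beyond the scatter) from compound 3 to compound 4, 43.7 percentage points apart, beyond the scatter of two such steps The result of this change on one core therefore gave no safe guide to its result on the other, and a rise seen once should not be treated as a rule for the whole series. For the compounds shown here, what this does not show is why the direction flips: the two cores differ in more than one place, each core offers only a single step of this kind, and these numbers cannot say which of the differences matters.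

The compounds shown leave open whether the read-out on each core would rise or fall along a still longer chain, so no best chain length can be named for either core. Also open, from the compounds shown here alone, is what an amine or a carboxylic acid would give at the end of the chain, in place of the end group that all four compounds share.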